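The compounds below may be only part of what the source reports. "The series", "measured", "known", "first", "only" and "open" are said of these compounds alone.

In a functional assay on MCF7 cells (Homo sapiens) for inhibition, read by sulforhodamine B assay (a higher number here means a weaker inhibitor of growth, a lower number a stronger inhibitor of growth), compound 2 (`CN(C)c1ccc(-c2ccc(-c3ccc(-c4nc5ccccc5[nH]4)cc3)cc2)cc1`) gives 41200 nM and compound 1 (`FC(F)(F)c1ccc(-c2ccc(-c3ccc(-c4nc5ccccc5[nH]4)cc3)cc2)cc1`) gives 41400 nM, so the two stand level within the scatter. Compound 3 (`COc1ccc(-c2ccc(-c3ccc(-c4nc5ccccc5[nH]4)cc3)cc2)cc1OC`) carries 3,4-dimethoxyphenyl in place of 4-(dimethylamino)phenyl on an aromatic carbon. Within the data shown here, one measured step bears on this change, dimethylamino in place of trifluoromethyl (a 1.0-fold lower number from compound 1 to compound 2 (0.00 log units; within the scatter)), and it lies within the scatter. On that single step, no change beyond the scatter is expected in this assay for compound 3. The estimated step (a 1.2-fold lower number from compound 2 to compound 3 (0.07 log units; within the scatter)) stays within the scatter. Compound 3 is estimated at 35000 nM (expected range 12000 nM to 80000 nM).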

Compound 3, concentration for 50% growth inhibition: 7600 nM
The estimate for compound 3 lay 4.6-fold (0.66 log units) above the measured number, outside the stated range (below it).
By their numbers in this assay, from the lowest: compound 3; then compounds 2 and 1 (each within the scatter of the next).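

In this assay, the group on this aromatic carbon, para to a large group, can shift the number after all: 3,4-dimethoxyphenyl gives a 5.4-fold lower number from compound 2 to compound 3 (0.73 log units; beyond the scatter) and a 5.4-fold lower number from compound 1 to compound 3 (0.74 log units; beyond the scatter) against the two earlier groups. Among these compounds, compounds 1 and 2 stood level, so the substituents at this position are not interchangeable, and this is the first change here beyond the scatter.

As far as these compounds go, whether a single methoxy group or a hydroxyl group would give the same step remains open. No measurement offers an explanation for the step.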